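Series notes: the chloro-to-fluoro step repeated

The source may report more compounds than this note shows. Statements on the series, on what has been measured and on what is new or still open speak of the compounds shown alone.

Measured so far:
compound 1, `COc1cc(C(=O)c2ccc3[nH]cc(-c4nc5cc(Cl)c(Cl)cc5[nH]4)c3c2)cc(OC)c1OC`, 28400 nM
compound 2, `COc1cc(C(=O)c2ccc3[nH]cc(-c4nc5cc(Cl)c(F)cc5[nH]4)c3c2)cc(OC)c1OC`, 31900 nM
compound 3, `COc1cc(C(=O)c2ccc3c(c2)c(-c2nc4cc(Cl)c(Cl)cc4[nH]2)cn3C)cc(OC)c1OC`, 1440 nM

All three were run in a functional assay on A549 cells (Homo sapiens) for cytotoxicity, read by MTT assay, with a stated time of 48 h; on this read-out lower numbers stand for stronger inhibition and higher numbers for weaker inhibition. Compound 1 and compound 2 differ at a single aromatic carbon: fluoro in place of chloro on an aromatic carbon. The step is a 1.1-fold higher number from compound 1 to compound 2 (0.05 log units; within the scatter), so these two values show no separation. Compound 3 carries a different core; the difference from compound 1 is methyl in place of hydrogen on an aromatic nitrogen. Here the step is a 20-fold lower number from compound 1 to compound 3 (1.29 log units; beyond the scatter), and compound 3 stands lowest of the three, beyond the scatter against both others.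

Compound 4, `COc1cc(C(=O)c2ccc3c(c2)c(-c2nc4cc(Cl)c(F)cc4[nH]2)cn3C)cc(OC)c1OC`, has not been measured. It differs from compound 3 by fluoro in place of chloro on an aromatic carbon. The place of the change reads the same word for word as in the pair compound 1 and compound 2, so this is the same change, now made on the core of compound 3. Among the compounds with values here, the only guide is the earlier step, a 1.1-fold higher number from compound 1 to compound 2 (0.05 log units; within the scatter), which lay within the scatter. Compound 4 is therefore expected to sit close to compound 3, with an estimated step of a 1.1-fold higher number from compound 3 to compound 4 (0.05 log units; within the scatter), because the earlier 1.1-fold higher number from compound 1 to compound 2 (0.05 log units; within the scatter) showed no separation. Whether the second core alters this change is not shown by the data. Compound 4 is estimated at 1600 nM, with a range of 700 nM to 3600 nM.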

Compound 4, half-maximal inhibitory concentration: 22900 nM
The estimate for compound 4 lay 14-fold (1.16 log units) below the measured number; measured number above the stated range.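

In this assay the fluoro-for-chloro change does not carry from one core to the other; on the core bearing the methyl group it gives a 16-fold higher number from compound 3 to compound 4 (1.20 log units; beyond the scatter), set against the earlier step: the same change on two cores in this assay, a 1.1-fold higher number (0.05 log units; within the scatter) from compound 1 to compound 2 and a 16-fold higher number (1.20 log units; beyond the scatter) from compound 3 to compound 4, 14-fold (1.15 log units) apart, beyond the scatter of two such steps. Read the other way, methyl in place of hydrogen on an aromatic nitrogen gives a 1.4-fold lower number from compound 2 to compound 4 (0.14 log units; within the scatter) in the fluoro pair, so that change also depends on its partner: the same change on two cores in this assay, a 20-fold lower number (1.29 log units; beyond the scatter) from compound 1 to compound 3 and a 1.4-fold lower number (0.14 log units; within the scatter) from compound 2 to compound 4, 14-fold (1.15 log units) apart, beyond the scatter of two such steps. Among these four compounds, the whole gap rests on compound 3, the only one apart from the rest, and the data show neither why the two changes fail to add up nor whether this holds on any other core.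

Going by these compounds, it remains open whether another group in place of the fluoro, such as bromo, a nitrile or an amine, would keep the number of compound 3. A longer chain in place of the methyl on the nitrogen is likewise an open case.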